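Butyl to tert-Butyl on the Amide of Compound 2

The source may report more compounds than this note shows. Statements on the series, on what has been measured and on what is new or still open speak of the compounds shown alone.

Compound 1 `Cn1cc(-c2ccc(F)cc2)c(=O)c2c(Nc3ccc(Oc4ccnc(NC(=O)C5CC5)c4)c(F)c3)nccc21`: 30.9%
Compound 2 `CCCCC(=O)Nc1cc(Oc2ccc(Nc3nccc4[nH]cc(-c5ccc(F)cc5)c(=O)c34)cc2F)ccn1`: 62.7%
Compound 3 `CC(C)(O)Cn1cc(-c2ccc(F)cc2)c(=O)c2c(Nc3ccc(Oc4ccnc(NC(=O)C5CC5)c4)c(F)c3)nccc21`: 44.3%

All three compounds were tested in a functional assay on MKN-45 cells (Homo sapiens) for antiproliferative activity, read by MTT assay, with a stated time of 72 h, tested at 10 uM; on this read-out lower numbers stand for less inhibition and higher numbers for more inhibition at the one concentration tested (going by the name of the read-out). Compound 2 stands highest of the three numbers, beyond the scatter above both compound 3 and compound 1. Among the compounds with values here, the only measured step between compounds that differ in one place is a number 13.4 percentage points higher from compound 1 to compound 3 (beyond the scatter), and that step concerns the group on the saturated chain carbon bound to an aromatic nitrogen, a different part of the shared core from the amide end.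

Compound 4 `CC(C)(C)C(=O)Nc1cc(Oc2ccc(Nc3nccc4[nH]cc(-c5ccc(F)cc5)c(=O)c34)cc2F)ccn1` differs from compound 2 by tert-butyl in place of butyl on a carbonyl carbon. Within the data shown here, no measured step touches the group on this carbonyl carbon, so the data give no direction for the change, and the expected step from compound 2 is a number 4.7 percentage points lower from compound 2 to compound 4 (within the scatter), which would lie within the scatter. On that basis compound 4 is estimated at 58%, with an expected range from 40% to 75%.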

Compound 4, a percentage reported as inhibition, at one concentration (the size of the read-out at that concentration, not a potency): 62.5%
The estimate for compound 4 lay 4.5 percentage points below the measured number; low and high end bracket the measured number.
By their numbers in this assay, from the lowest: compound 1; then compound 3; then compounds 4 and 2 (each within the scatter of the next).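

In this assay, putting tert-butyl in place of butyl on a carbonyl carbon whose other neighbour is an amide-type nitrogen gives a number 0.2 percentage points lower from compound 2 to compound 4 (within the scatter). Within the data shown here, this is the only measured change at this position, and it shows that the same four carbons, joined either as a straight chain or as a branched one, give numbers that cannot be told apart at the one concentration tested. No measurement shown here offers an explanation for this result.

As far as these compounds go, both groups contain only carbon and hydrogen, so it remains open whether an amine, a carboxylic acid or a longer chain such as octyl on this carbonyl carbon would shift the number beyond the scatter. A reading at one concentration also leaves open whether compound 2 and compound 4 would match in potency.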